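The source may report more compounds than this note shows. Statements on the series, on what has been measured and on what is new or still open speak of the compounds shown alone.

Compound 1 `Oc1c(CN2CCCC2)ccc2cccnc12`: 1470 nM; 1450 nM (2 entries)
Compound 2 `Oc1c(CN2CCCC2)cc(Cl)c2cccnc12`: 300 nM; 295 nM (2 entries)
Compound 3 `Oc1c(CN2CCCC2)cc(Br)c2cccnc12`: 389 nM

All of these values come from a functional assay on MES-SA/Dx5 cells (Homo sapiens) for inhibition, with a stated time of 72 h; a lower number here means a stronger inhibitor, a higher number a weaker inhibitor. Compound 3 stands on one number, 389 nM, and its two further entries give no single number. Compound 2 gives 300 nM; 295 nM (2 entries), which is within the scatter of the value of compound 3. Compound 1, which carries neither chlorine nor bromine, gives a higher value, 1470 nM; 1450 nM (2 entries).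

Compound 4 `COCc1cc(CN2CCCC2)c(O)c2ncccc12` has not yet been measured. It differs from compound 3 by methoxymethyl in place of bromo on an aromatic carbon, with methoxymethyl in place of bromo on an aromatic carbon. Among the compounds with values here, no measured compound carries methoxymethyl, so the expectation is loose. It rests on compound 1 at 1470 nM; 1450 nM (2 entries), and compound 4 is expected to fall towards that value without quite reaching it. The estimated change is a weakening a little beyond the scatter, a 2.3-fold higher number from compound 3 to compound 4 (0.36 log units; beyond the scatter). For compound 4 the estimated value is 900 nM, with an expected range from 350 nM to 2300 nM.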

Compound 4, half-maximal inhibitory concentration: 1350 nM
The estimate for compound 4 lay 1.5-fold (0.18 log units) below the measured number; the range from low to high includes it.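

The step of a 3.5-fold higher number from compound 3 to compound 4 (0.54 log units; beyond the scatter) shows in this assay that this position, on an aromatic carbon para to a hydroxy group, does not accept every replacement for bromo equally. Methoxymethyl, with its 3 heavy atoms and 1 hydrogen-bond acceptor, gives up the advantage seen with the halogens: compound 4 at 1350 nM lies close to compound 1, which carries neither chlorine nor bromine, so among the compounds shown only chloro and bromo go with the lower numbers. The reference point for this reading is itself consistent: the several entries of compound 1 in this assay, 1470 nM; 1450 nM (2 entries)

The compounds shown leave open whether a methyl, a nitrile or an amine at this position would behave like the halogens or like methoxymethyl. They also leave open whether a shorter ether such as methoxy would fare differently, and they contain no measurement that explains the loss.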